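Swapping cyclohexyl for phenyl in a chloroacetyl urea

The compounds below may be only part of what the source reports. "The series", "measured", "known", "first", "only" and "open" are said of these compounds alone.

Compound 1 `c1ccc(Oc2ccc(NC3=NCCO3)cc2)cc1`: 3100 nM
Compound 2 `O=C(CCl)NC(=O)Nc1ccc(OC2CCCCC2)cc1`: 5000 nM

Both compounds were tested in a functional assay on M21 cells (Homo sapiens) for inhibition, read by sulforhodamine B assay, with a stated time of 48 h; a higher number here means a weaker inhibitor of growth, a lower number a stronger inhibitor of growth. Compound 2 gives 5000 nM and compound 1 gives 3100 nM. These two numbers lie within the usual scatter of each other, so they cannot be ranked. The two structures also differ in more than one place, so this pair says little about any single group.

The next compound is compound 3 `O=C(CCl)NC(=O)Nc1ccc(Oc2ccccc2)cc1`. It keeps the rest of compound 2 and has phenyl in place of cyclohexyl on an oxygen on an aromatic ring. In other words, cyclohexyloxy becomes phenoxy.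

Among the compounds with values here, no measured pair shows this change directly, so the expectation rests on thin evidence. Compound 1 already carries phenoxy on a different remainder and gives 3100 nM, so a number in that region seems reasonable. No step beyond the scatter is expected, with at most a slight lean towards a lower number. The estimated change is a 1.4-fold lower number from compound 2 to compound 3 (0.15 log units; within the scatter). For compound 3 the expected value is 3500 nM, with an estimated range from 1300 nM to 9000 nM.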

Compound 3, concentration for 50% growth inhibition: 4200 nM
Compound 3: middle estimate off by 1.2-fold (0.08 log units), on the low side, within the range that was stated.
By their numbers in this assay, from the lowest: compounds 1, 3 and 2 (each within the scatter of the next).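

In this assay, putting phenyl in place of cyclohexyl on an oxygen on an aromatic ring gives a 1.2-fold lower number from compound 2 to compound 3 (0.08 log units; within the scatter), so this position does not separate an aromatic six-membered carbon ring from a non-aromatic one. Within the data shown here, this is the first comparison in which only that ring differs, and the result is a step within the scatter rather than a real gain or loss. Compound 3 also allows a one-place comparison with compound 1: with phenoxy kept, the chloroacetyl urea on the nitrogen stands in place of the five-membered non-aromatic ring group, giving a 1.4-fold higher number from compound 1 to compound 3 (0.13 log units; within the scatter), which also lies within the scatter, so these two quite different groups cannot be told apart here. No other measurement on these compounds is available that could explain these results.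

The compounds shown leave open whether anything on this oxygen can move the number beyond the scatter, for example a plain methyl group, or a phenyl ring carrying an amine or a carboxylic acid. They also leave open what the chlorine contributes, since a plain acetyl urea in place of the chloroacetyl urea is not among them.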